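The source may hold more compounds than are shown below. What is called first, only, known or untested is meant among the compounds shown, and "the series" means these compounds.

Compound 1 `CCOC(=O)[C@H](CCC(=O)O)NC(=O)c1ccc(CNc2nc3cc(N)cc(N)c3nc2-c2ccccc2)cc1`: in a functional assay on SF-268 cells (Homo sapiens) for inhibition, read by sulforhodamine B assay, with a stated time of 48 h (on this read-out higher numbers stand for lower toxicity in this test and lower numbers for higher toxicity in this test), compound 1 reaches only the limit < 100000 nM.
Compound 2 `Nc1cc(N)c2nc(-c3ccccc3)c(NCc3ccc(F)cc3)nc2c1`: in this assay compound 2 gives 40700 nM.
Compound 3 `COc1ccc(Sc2nc3cc(N)cc(N)c3nc2-c2ccccc2)cc1`: in this assay compound 3 reaches only the limit < 100000 nM.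

Compound 3 thus stands at the limit of < 100000 nM in this assay, at which 2 of the 3 values shown sit, so its exact position is not known. Compound 4 `Nc1cc(N)c2nc(-c3ccccc3)c(Oc3ccc(F)cc3)nc2c1` differs from it in one place: 4-fluorophenoxy in place of (4-methoxyphenyl)sulfanyl on an aromatic carbon. Going by the values given here, the only measured step that touches this position is a step that the limit leaves unreadable from compound 2 to compound 3, and it cannot be read because of the limit on compound 3. Among the compounds with values here, no step therefore tells how large or in which direction the change to compound 4 will act, and a value around that of compound 2 is as plausible as a return to the limit. Compound 4 is estimated to give 45000 nM, between 12000 nM and 100000 nM, an expected step that the limit leaves unreadable from compound 3 to compound 4.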

Compound 4, concentration lethal to 50% of the cells: < 100000 nM
Compound 4 gave a limit, no number (the forecaster's own chance of this, stated with the estimate: 40%); the middle value does not contradict the limit.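

Compound 4 also stops at a limit, so the steps linking it to compound 2 and compound 3 cannot be read: the limit of < 100000 nM in this assay, at which 3 of the 4 values shown sit.

The compounds shown leave open whether compound 3 and compound 4 truly differ from compound 2 or from each other in this assay.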